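A Methyl-to-Ethyl Step at Compound 3

This account rests on a few compounds, and the source may have more. Where it says the series, first, only, none or still open, it means among the compounds named here.

In a functional assay on DU-145 cells (Homo sapiens) for inhibition, read by CCK-8 assay, with a stated time of 72 h (on this read-out higher numbers stand for weaker inhibition and lower numbers for stronger inhibition), compound 1 (`O=C(/C=C/c1cccnc1)NCCCCCCc1ccc(S(=O)(=O)Nc2ccccc2)cc1`) gives 328 nM and compound 2 (`Cc1ccc(NS(=O)(=O)c2cccc(CCCCCCNC(=O)/C=C/c3cccnc3)c2)cc1`) gives 34.4 nM as the lower of the two numbers, which places it on the stronger side by a gap beyond the scatter. Compound 3 (`CCc1ccc(NS(=O)(=O)c2cccc(CCCCCCNC(=O)/C=C/c3cccnc3)c2)cc1`) departs from compound 2 by a single change (methyl in place of hydrogen on a saturated chain carbon bound to an aromatic carbon), methyl in place of hydrogen on a saturated chain carbon bound to an aromatic carbon, so that 4-methylphenyl becomes 4-ethylphenyl. Among the measured compounds shown here, no measured pair shows this change. Starting from compound 2 at 34.4 nM and given so limited a change, a slight weakening at most, probably within the scatter, is expected in this assay for now. The expected step is a 1.2-fold higher number from compound 2 to compound 3 (0.09 log units; within the scatter) and it is estimated to stay small. For compound 3 the expected value is 42 nM within an estimated range of 15 nM to 115 nM in this assay once measured.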

Compound 3, half-maximal inhibitory concentration: 40.1 nM
The estimate for compound 3 lay 1.0-fold (0.02 log units) above the measured number; the measured number falls inside the stated range.
By their numbers in this assay, from the lowest: compounds 2 and 3 (each within the scatter of the next); then compound 1.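

In this assay the change from 4-methylphenyl to 4-ethylphenyl amounts to a 1.2-fold higher number from compound 2 to compound 3 (0.07 log units; within the scatter) and so leaves the two compounds indistinguishable on this read-out. This is the first pair shown that differs in one place, and it indicates that this position accepts methyl in place of hydrogen on a saturated chain carbon bound to an aromatic carbon without a change that can be read. No measurement that could account for this result is available.

As far as these compounds go, whether this holds for a longer chain such as propyl or for a branched group such as tert-butyl remains open. The compounds shown also do not settle how an amine, a methoxy group or a carboxylic acid in the place of the ethyl group would read in this assay and whether such a group would stay in the same range.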